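The compounds below may be only part of what the source reports. "The series", "measured", "known", "first", "only" and "open" are said of these compounds alone.

Measured compounds in a functional assay on the whole organism (strain albino) for inhibition, with Rattus norvegicus as the target, read by paw edema, with stated times of 1 h and 3 h, at a dose of 20 mmol/kg by the intraperitoneal route; a lower number here means a weaker effect, a higher number a stronger effect of the compound at the dose given:
compound 1 `N#CC1=C(NCC(=O)N2CCOCC2)N(c2ccccc2)C(=O)N2CCCCC(N3CCCC3)C12` gives 73.5%
compound 2 `N#CC1=C(/N=C/Nc2ccc([N+](=O)[O-])cc2)N(c2ccccc2)C(=O)N2CCCCC(N3CCCC3)C12` gives 85.6%
compound 3 `COc1ccc(N/C=N/C2=C(C#N)C3C(N4CCCC4)CCCCN3C(=O)N2c2ccccc2)cc1` gives 50.2%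

Compound 3 stands lowest of the three in this assay, with a number 23.3 percentage points lower from compound 1 to compound 3 (beyond the scatter) and a number 35.4 percentage points lower from compound 2 to compound 3 (beyond the scatter). Compound 4 `N#CC1=C(NCN2CCCCC2)N(c2ccccc2)C(=O)N2CCCCC(N3CCCC3)C12` differs from compound 3 in one place: a group of 8 heavy atoms (6 carbon, 2 nitrogen; one six-membered non-aromatic ring with 1 hetero atom) in place of a group of 11 heavy atoms (8 carbon, 2 nitrogen, 1 oxygen; one six-membered aromatic ring of carbon only), on a double-bonded ring carbon. The step that bears on this is the earlier exchange of a six-membered non-aromatic ring for a six-membered aromatic ring on the same double-bonded ring carbon, a number 23.3 percentage points lower from compound 1 to compound 3 (beyond the scatter), a modest loss. Compound 4 again carries a six-membered non-aromatic ring there, so a partial return towards the number of compound 1 is expected. In this assay a rise of a number 14.8 percentage points higher from compound 3 to compound 4 (beyond the scatter) is expected. The estimate for compound 4 is 65%, with a range from 48% to 80%.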

Compound 4, a percentage reported as inhibition, in the whole organism at one dose (the size of the read-out at that dose, not a potency): 42.1%
For compound 4 the middle estimate is 22.9 percentage points above the measured one; measured number below the stated range.
By their numbers in this assay, from the lowest: compounds 4 and 3 (each within the scatter of the next); then compound 1; then compound 2.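

In this assay, a non-aromatic ring on this double-bonded ring carbon does not by itself restore the number of compound 1: with piperidin-1-yl in place of (morpholin-4-yl)carbonyl on the saturated chain carbon, the step is a number 31.4 percentage points lower from compound 1 to compound 4 (beyond the scatter). The other steps are a number 8.1 percentage points lower from compound 3 to compound 4 (within the scatter) and a number 43.5 percentage points lower from compound 2 to compound 4 (beyond the scatter), so aromatic versus non-aromatic ring does not sort the series, with compound 1 and compound 2 both going against such a split. Nothing available here accounts for these steps.

Going by these compounds, whether the carbonyl or the ring exchange carries the step from compound 1 stays open. (Piperidin-1-yl)carbonyl on the same chain carbon would separate the two.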